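Cyclopropyl for dimethoxyphenyl: outlook for cytotoxicity

This account rests on a few compounds, and the source may have more. Where it says the series, first, only, none or still open, it means among the compounds named here.

Three compounds in this set share one core and were all tested in an ADME assay on HeLa cells (Homo sapiens) for cytotoxicity, read by ATP content, with a stated time of 3 days; on this read-out higher numbers stand for lower toxicity in this test and lower numbers for higher toxicity in this test. Compound 1 `CS(=O)(=O)CCCn1c(Cn2c(=O)n(C3CC3)c3ccncc32)cc2cc(Cl)ccc21` returns only a limit of the assay, > 50000 nM. Compound 2 `O=c1n(Cc2cc3cc(Cl)ccc3n2CCCC(F)(F)F)c2cnccc2n1C1CC1` likewise returns only a limit, > 50000 nM. Within the data shown here, the single measured step between them, a step that the two limits leave unreadable from compound 1 to compound 2, therefore cannot be read in size or direction, and it does not bear on the change considered here. Compound 3 `COc1ccc(-n2c(=O)n(Cc3cc4cc(Cl)ccc4n3CCCC#N)c3cnccc32)cc1OC` also stands at a limit, > 50000 nM. That is the same limit at which every value in this set sits (the limit of > 50000 nM in this assay, at which 3 of the 3 values shown sit), so nothing more exact is known of where compound 3 stands.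

Compound 4 `N#CCCCn1c(Cn2c(=O)n(C3CC3)c3ccncc32)cc2cc(Cl)ccc21` has not yet been measured. It differs from compound 3 in one place: cyclopropyl in place of 3,4-dimethoxyphenyl on an aromatic nitrogen. Among the measured compounds shown here, no measured step follows this particular change. Compounds 1 and 2 already carry the cyclopropyl group that enters in compound 4, and both show only the limit. On that basis the step expected for compound 4 is a step that the limit leaves unreadable from compound 3 to compound 4, meaning no change beyond the scatter, with compound 4 most likely staying at the limit as well. The value estimated for compound 4 is 60000 nM, within a range from 25000 nM to 150000 nM.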

Compound 4, half-maximal cytotoxic concentration: > 50000 nM
Compound 4 was reported as a limit (the forecaster's own chance of this, stated with the estimate: 85%); the middle value is on the limit's open side.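

Compound 4 also returns only a limit, so its steps from compound 1, compound 2 and compound 3 cannot be read in this assay, in size or in direction: the limit of > 50000 nM in this assay, at which 4 of the 4 values shown sit.

The compounds shown leave open whether swapping cyclopropyl for 3,4-dimethoxyphenyl, or changing the group at the chain end, alters toxicity in this assay at all.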